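Chain Lengthening Between Aromatic Amine and Dimethylamino Terminus

This account rests on a few compounds, and the source may have more. Where it says the series, first, only, none or still open, it means among the compounds named here.

Measured compounds:
compound 1, `CN(C)CCCNc1ccnc2cc(OCc3ccc(F)cc3)ccc12`, 490 nM
compound 2, `CCOc1ccc2c(NCCN(C)C)ccnc2c1`, 2520 nM

In a functional assay on BGC-823 cells (Homo sapiens) for cytotoxicity, read by MTT assay, with a stated time of 48 h (on this read-out higher numbers stand for weaker inhibition and lower numbers for stronger inhibition), compound 2 gives the higher of the two numbers recorded so far. Its nearest neighbour, compound 1, gives 490 nM, a gap that lies beyond the usual scatter. Among the compounds with values here, compound 2 and compound 1 differ in more than one place, so their two values show only that compound 2 stands weaker here.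

Compound 3, `CCOc1ccc2c(NCCCN(C)C)ccnc2c1`, has not yet been measured. It differs from compound 2 by (dimethylamino)methyl in place of dimethylamino on a saturated chain carbon, two bonds along the chain from a nitrogen on an aromatic ring, that is, the chain between the aromatic amine and the terminal amine grows by one carbon.

Within the data shown here, no step of this kind among measured compounds is available. A modest move toward a lower number in this assay is expected, possibly not beyond the scatter, as the step of a 1.7-fold lower number from compound 2 to compound 3 (0.23 log units; within the scatter). Compound 3 is estimated at 1500 nM, in the range 500 nM to 4500 nM.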

Compound 3, half-maximal inhibitory concentration: 9810 nM
Compound 3: middle estimate off by 6.5-fold (0.82 log units), on the low side, outside the stated range (above it).
By their numbers in this assay, from the lowest: compound 1; then compound 2; then compound 3.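

In this assay the one-carbon growth of the chain, (dimethylamino)methyl in place of dimethylamino, gives a 3.9-fold higher number from compound 2 to compound 3 (0.59 log units; beyond the scatter), so this position responds to chain length, and here the longer chain goes with weaker inhibition. Within the data shown here, the other change, methyl in place of 4-fluorophenyl on a saturated chain carbon bound to an oxygen on an aromatic ring, gives a 20-fold higher number from compound 1 to compound 3 (1.30 log units; beyond the scatter), the larger of the two steps and the first reading of that place with only one change. Nothing measured here accounts for either step.

As far as these compounds go, whether the chain step holds when 4-fluorophenyl is present remains open. So does the outcome of a still longer chain, or of a pyrrolidine or morpholine in place of the terminal dimethylamino.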